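The source may report more compounds than this note shows. Statements on the series, on what has been measured and on what is new or still open speak of the compounds shown alone.

Compound 1 `Cc1ccc(-c2nn(-c3ccccc3)cc2-c2nc3ccccc3n2S(=O)(=O)c2ccc(Br)cc2)cc1` and compound 2 `Cc1ccc(-c2nn(-c3ccccc3)cc2-c2nc3ccccc3n2S(=O)(=O)c2ccc(C(F)(F)F)cc2)cc1` share one core. In an ADME assay on HEK-293T cells (Homo sapiens) for cytotoxicity, read by MTT assay, with a stated time of 24 h (a higher number here means that more compound is tolerated, a lower number that less compound is tolerated), compound 1 gives 159000 nM, and compound 2 gives 182000 nM. The change between them is trifluoromethyl in place of bromo on an aromatic carbon, and it made a 1.1-fold higher number from compound 1 to compound 2 (0.06 log units; within the scatter). Compound 3 `O=S(=O)(c1ccc(Br)cc1)n1c(-c2cn(-c3ccccc3)nc2-c2ccc(F)cc2)nc2ccccc21` carries a different core; the difference is fluoro in place of methyl on an aromatic carbon. In this assay compound 3 gives 239000 nM, which is a 1.5-fold higher number from compound 1 to compound 3 (0.18 log units; within the scatter). Compound 4 `O=S(=O)(c1ccc(C(F)(F)F)cc1)n1c(-c2cn(-c3ccccc3)nc2-c2ccc(F)cc2)nc2ccccc21` has not yet been measured. It differs from compound 3 by trifluoromethyl in place of bromo on an aromatic carbon, the same change that turned compound 1 into compound 2. Because that earlier change gave only a 1.1-fold higher number from compound 1 to compound 2 (0.06 log units; within the scatter), a similarly small step is expected here as well, namely a 1.1-fold higher number from compound 3 to compound 4 (0.04 log units; within the scatter). Compound 4 is therefore estimated at 260000 nM, with an expected range from 150000 nM to 450000 nM.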

Compound 4, half-maximal cytotoxic concentration: 241000 nM
Estimate against measurement, compound 4: 1.1-fold (0.03 log units) above; low and high end bracket the measured number.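

The step of a 1.0-fold higher number from compound 3 to compound 4 (0.00 log units; within the scatter) matches the one seen for the same swap of bromo for trifluoromethyl on the other core: the same change on two cores in this assay, a 1.1-fold higher number (0.06 log units; within the scatter) from compound 1 to compound 2 and a 1.0-fold higher number (0.00 log units; within the scatter) from compound 3 to compound 4, 1.1-fold (0.06 log units) apart, within the scatter of two such steps. Fluoro in place of methyl gives a step of a 1.3-fold higher number from compound 2 to compound 4 (0.12 log units; within the scatter), and this also matches its earlier counterpart: the same change on two cores in this assay, a 1.5-fold higher number (0.18 log units; within the scatter) from compound 1 to compound 3 and a 1.3-fold higher number (0.12 log units; within the scatter) from compound 2 to compound 4, 1.1-fold (0.06 log units) apart, within the scatter of two such steps. Within the data shown here, both changes therefore carry across these two cores without a visible difference, but every step lies within the scatter, so this shows only that neither change measurably moved the number in this assay, and it does not show how either change would behave on any other core.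

On these data alone, it remains open whether any change at these two places can move the number beyond the scatter. An amine or a carboxylic acid in place of bromo or fluoro would be a much larger change than any of the four compounds shown here covers.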